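Aryl amide swap at the carbonyl: compound 3 to compound 4

The source may report more compounds than this note shows. Statements on the series, on what has been measured and on what is new or still open speak of the compounds shown alone.

Of the compounds shown here, three so far carry numbers in a functional assay on the whole organism (blood) with Rattus norvegicus as the target, with stated times of 24 h and 1 h, at a dose of 5 mg/kg by the intraperitoneal route; on this read-out lower numbers stand for a weaker effect and higher numbers for a stronger effect at the one dose given. Compound 1 `COc1ccc(NC(=O)NS(=O)(=O)N2CCC(CCNC(=O)c3cc(Cl)ccc3OC)CC2)cc1` gives 27%. Compound 2 `CCCNC(=O)NS(=O)(=O)N1CCC(CCNC(=O)c2cc(C(F)(F)F)nn2C)CC1` gives 11%. Compound 3 `COc1ccncc1C(=O)NCCC1CCN(S(=O)(=O)NC(=O)NC[C@@H]2C[C@@H]3C=C[C@@H]2C3)CC1` gives 14%, the second highest of the three numbers; its gap to compound 2 lies within the scatter, while compound 1 stands beyond the scatter above it. Compound 4 `O=C(NC[C@@H]1C[C@@H]2C=C[C@@H]1C2)NS(=O)(=O)N1CCC(CCNC(=O)c2cc(Cl)cc3cccnc23)CC1` awaits measurement in this assay. It differs from compound 3 in one place: 6-chloroquinolin-8-yl in place of 4-methoxypyridin-3-yl on a carbonyl carbon. Among the measured compounds shown here, no measured pair differs in a single place, so no measured step is available as a guide. A step from compound 3 to compound 4 of about a number 6 percentage points higher from compound 3 to compound 4 (within the scatter) is expected, upward but not clearly beyond the scatter. For compound 4 the estimate is 20%, within a range from 8% to 38%.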

Compound 4, a percentage reported as activity, at one dose (the size of the read-out at that dose, not a potency): 35%
Compound 4: middle estimate off by 15 percentage points, on the low side; measured number inside the range.
By their numbers in this assay, from the lowest: compounds 2 and 3 (each within the scatter of the next); then compounds 1 and 4 (each within the scatter of the next).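

In this assay, among the compounds shown here, the carbonyl position is sensitive to the choice of aromatic group: 6-chloroquinolin-8-yl in place of 4-methoxypyridin-3-yl gives a number 21 percentage points higher from compound 3 to compound 4 (beyond the scatter) and is the first single-place step. This one change replaces the methoxy oxygen with chlorine and adds a second aromatic ring, so the step cannot assign the gain to either feature. No measured data on hand explain the rise.

On these data alone, the separate contributions of the chlorine and the second ring remain open. Unsubstituted quinolin-8-yl on the same carbonyl carbon would help separate them.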